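A few compounds are considered here, and "the series" means these few. Any claim that something is new, unique, unknown or untested is made for them only; others in the source may bear on it.

In a functional assay on A549 cells (Homo sapiens) for inhibition, read by sulforhodamine B assay, with a stated time of 74 h (a higher number here means a weaker inhibitor, a lower number a stronger inhibitor), two compounds sharing one core have been measured so far. Compound 1 `O=C1C=CC2(C=C1)OCC(=O)N2S(=O)(=O)c1ccc(Cl)cc1`, which carries chloro on the aromatic ring, reads > 10000 nM, and this is a limit of the assay, not a number. For the measured compounds named here, compound 2 `O=C1C=CC2(C=C1)OCC(=O)N2S(=O)(=O)c1ccc(N2CCCC2=O)cc1`, which carries 2-oxopyrrolidin-1-yl at that place, gives 5 nM, the only actual number available, so there is no measured series against which to rank it. Compound 3 `O=C1C=CC2(C=C1)OCC(=O)N2S(=O)(=O)c1ccc(OC(F)(F)F)cc1` keeps the shared core and changes that same place, with trifluoromethoxy in place of 2-oxopyrrolidin-1-yl on an aromatic carbon. Going by the values given here, the one measured step that bears on this is an at least 2000-fold lower number from compound 1 to compound 2 (3.30 log units; beyond the scatter), where 2-oxopyrrolidin-1-yl replaced chloro and the change was large. Compound 3 gives up that same group, so a large move in this assay towards a higher number, meaning a weaker inhibitor, is expected. Trifluoromethoxy itself has not been measured on this core, so the size remains uncertain. The estimated change is a 300-fold higher number from compound 2 to compound 3 (2.48 log units; beyond the scatter). For compound 3 the estimate is 1500 nM, with an expected range from 50 nM to 10000 nM.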

Compound 3, half-maximal inhibitory concentration: 40 nM
Compound 3: the middle estimate sits 38-fold (1.57 log units) above what was measured; the whole stated range lies above it.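

In this assay, this place on the aromatic ring does not depend on 2-oxopyrrolidin-1-yl alone for a low reading: replacing it with trifluoromethoxy, a group with no ring, gives an 8.0-fold higher number from compound 2 to compound 3 (0.90 log units; beyond the scatter), so the step is real but modest. The sharp divide seen earlier therefore also separates chloro from a second, quite different group, as trifluoromethoxy in place of chloro gives an at least 250-fold lower number from compound 1 to compound 3 (2.39 log units; beyond the scatter). The reading for compound 1 is a limit of the assay and not a number: the limit of > 10000 nM in this assay, at which 1 of the 3 values shown sits.

For the compounds shown here, with only three groups at this place, it remains open whether chloro is an unusual case or whether low readings need something particular that trifluoromethoxy and 2-oxopyrrolidin-1-yl share, and a methoxy group, an amine or a carboxylic acid at the same place would help to tell these apart. An open-chain amide would ask a separate question, namely whether the ring of 2-oxopyrrolidin-1-yl contributes to the lower number of compound 2 or whether the amide alone would be enough.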